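A few compounds are considered here, and "the series" means these few. Any claim that something is new, unique, unknown or untested is made for them only; others in the source may bear on it.

In a physicochemical assay for lipophilicity, read by mass spectrometry (on this read-out lower numbers stand for lower lipophilicity and higher numbers for higher lipophilicity), compound 1 (`COc1cc2c(cc1OC)C(=O)C(C(=O)Nc1ccc(F)cc1)C2`) gives 2.36 while compound 2 (`COc1cc2c(cc1OC)C(=O)C(C(=O)Nc1ccc(Br)cc1)C2`) gives 3.03 and compound 3 (`CCc1cccc(NC(=O)C2Cc3cc(OC)c(OC)cc3C2=O)c1`) gives 3.11 on the shared core. Compound 3 therefore shares the top of this small range with compound 2 and stands clear of compound 1. Compound 4 (`COc1cc2c(cc1OC)C(=O)C(C(=O)Nc1ccccc1C)C2`) has 2-methylphenyl in place of 3-ethylphenyl on an amide-type nitrogen and has not yet been measured.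

Among the compounds with values here, two measured steps concern this same place. The first is a number 0.75 log units higher from compound 1 to compound 3 (beyond the scatter) and is modest. The second is a number 0.08 log units higher from compound 2 to compound 3 (within the scatter) and cannot be told from no change. A third step, the exchange of fluoro for bromo, is a number 0.67 log units higher from compound 1 to compound 2 (beyond the scatter) and is also modest. Within the data shown here, no measured compound carries 2-methylphenyl, so the estimate has no direct precedent. Since compound 3 starts at 3.11 at the top of the range, a modest fall in this assay is expected, somewhat smaller than the gap to compound 1. The expected change is a number 0.51 log units lower from compound 3 to compound 4 (beyond the scatter) as an estimate with wide margins. Compound 4 is estimated to read 2.6 within an expected range of 2.25 to 2.95 when it is measured.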

Compound 4, partition coefficient: 2.69
Compound 4: the middle estimate sits 0.09 log units below what was measured; the range from low to high includes it.
By their numbers in this assay, from the lowest: compound 1; then compound 4; then compounds 2 and 3 (each within the scatter of the next).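

Until now the groups on the amide-type nitrogen fell into two levels, compound 1 alone and compounds 2 and 3 together, and compound 4 shows that this place can also give a reading in between. In this assay the change to 2-methylphenyl is a number 0.42 log units lower from compound 3 to compound 4 (beyond the scatter), while the other two comparisons are a number 0.34 log units lower from compound 2 to compound 4 (beyond the scatter) and a number 0.33 log units higher from compound 1 to compound 4 (beyond the scatter), so compound 4 stands apart from all three. Groups of carbon only can therefore differ at this place: 3-ethylphenyl, with 8 heavy atoms, and 2-methylphenyl, with 7, give separate readings although neither carries a hydrogen-bond donor, a hydrogen-bond acceptor or a net charge.

From the compounds shown here alone, the step from compound 3 to compound 4 changes both the chain and its place on the ring, so the two cannot be separated, and how a phenyl group bearing an amine or a carboxylic acid would read on this nitrogen remains open. Nothing given here offers a measured explanation for any of these steps.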